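The compounds below may be only part of what the source reports. "The series", "measured", "known", "first", "only" and "open" are said of these compounds alone.

Three compounds share the same core and differ in two spots. Compound 1 `Cc1ccc2c(=O)c(CSC(=S)N3CCCCC3)coc2c1` gives 1700 nM in a functional assay on MDA-MB-435S cells (Homo sapiens) for antiproliferative activity, read by MTT assay, with a stated time of 72 h (on this read-out lower numbers stand for stronger inhibition and higher numbers for weaker inhibition), compound 2 `O=c1c(CSC(=S)N2CCCCC2)coc2cc(Cl)ccc12` gives 240 nM, and compound 3 `O=c1c(CSC(=S)N2CCOCC2)coc2ccccc12` gives 3900 nM. Going by the values given here, compound 2 stands lowest of the three numbers, and the step of a 7.1-fold lower number from compound 1 to compound 2 (0.85 log units; beyond the scatter) is the only single change measured, a chloro in place of a methyl on an aromatic carbon. Compound 4 `CC(C)N(C(=S)SCc1coc2cc(Cl)ccc2c1=O)C(C)C` carries diisopropylamino in place of piperidin-1-yl on a thiocarbonyl carbon. Among the compounds with values here, no measured step alters the amine on the thiocarbonyl carbon alone, since compound 3 differs from compound 2 in two places at once, so the measured steps give little guidance here. Compound 4 is therefore expected to stay close to compound 2, with a step of a 1.7-fold higher number from compound 2 to compound 4 (0.22 log units; within the scatter) not clearly beyond the scatter, and its expected value in this assay is 400 nM, between 120 nM and 1300 nM.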

Compound 4, half-maximal inhibitory concentration: > 25000 nM
Compound 4: a limit, no number; the forecaster's own chance of this, stated with the estimate: 3%; middle value at least 62-fold (1.79 log units) from the limit.
By their numbers in this assay, from the lowest: compound 2; then compound 1; then compound 3. At a limit, above all of these: compound 4.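

With the rest of compound 2 unchanged, diisopropylamino in place of piperidin-1-yl on a thiocarbonyl carbon gives an at least 100-fold higher number from compound 2 to compound 4 (2.01 log units; beyond the scatter) in this assay. Going by these compounds alone, this is the first change measured at this place alone, and it shows that the amine there can decide whether any activity is seen in this assay. For compound 4 the result is a limit and not a number: the limit of > 25000 nM in this assay, at which 1 of the 4 values shown sits.

On these data alone, it remains open whether an open-chain amine such as dimethylamino, or a ring such as pyrrolidin-1-yl, would keep the activity of compound 2. Compound 3 differs from compound 2 in two places, so it cannot settle this.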